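Adding a Carboxy Group to the Phenyl Ring of Compound 2

This account rests on a few compounds, and the source may have more. Where it says the series, first, only, none or still open, it means among the compounds named here.

Measured so far:
compound 1 `CC1CCC(=NN(C)c2ccccc2)c2ncc(C(=O)O)c(=O)n21`: 52.4 umol/kg
compound 2 `CC1CCC(C)(N=Nc2ccccc2)c2ncc(C(=O)O)c(=O)n21`: 35 umol/kg

Of the compounds shown here, two have been tested in a functional assay on the whole organism with Rattus norvegicus as the target; on this read-out higher numbers stand for an effect only at larger amounts of compound and lower numbers for an effect already at smaller amounts. Compound 1 gives 52.4 umol/kg in this assay, and compound 2 gives 35 umol/kg. Compound 2 carries the lowest of the two numbers, but the gap to compound 1 lies within the usual scatter of repeated measurements, so the two compounds cannot be told apart on these data.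

Compound 3 `CC1CCC(C)(N=Nc2ccccc2C(=O)O)c2ncc(C(=O)O)c(=O)n21` is the next compound to be measured. It differs from compound 2 in one place: carboxy in place of hydrogen on an aromatic carbon. Among the compounds with values here, no pair of measured compounds shows this change, so there is nothing in the measured set to say how the carboxy group on the phenyl ring will shift the dose.

With only compound 2 to go on, the step of a 1.3-fold higher number from compound 2 to compound 3 (0.11 log units; within the scatter) is expected to stay within the scatter, leaning if anything toward a somewhat higher number. Compound 3 is therefore estimated at 45 umol/kg, with a plausible range from 15 umol/kg to 150 umol/kg.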

Compound 3, dose for 50% inhibition: > 100 umol/kg
Compound 3 gave a limit, no number (the forecaster's own chance of this, stated with the estimate: 10%); middle value at least 2.2-fold (0.34 log units) from the limit.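

The phenyl ring of compound 2 turns out not to be a place where any added group is tolerated: in this assay, carboxy in place of hydrogen on an aromatic carbon, ortho to a large group, gives an at least 2.8-fold higher number from compound 2 to compound 3 (0.45 log units; beyond the scatter). Within the data shown here, this is the first measured change on that ring, and it shows that a single small substituent there can move the dose beyond the usual scatter, toward larger amounts of compound. The size of the shift remains a lower bound, since the reading for compound 3 is a limit of the assay and not a number: the limit of > 100 umol/kg in this assay, at which 1 of the 3 values shown sits.

From the compounds shown here alone, with only this one substitution on the ring, the data cannot separate the effect of the carboxy group itself from the effect of the place it occupies, and the true dose of compound 3 remains unknown. A methyl ester, an amide or a plain methyl group at this same place, or a carboxy group on another carbon of the phenyl ring, would be needed to tell whether the group or the position matters more.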